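The source may report more compounds than this note shows. Statements on the series, on what has been measured and on what is new or still open speak of the compounds shown alone.

Measured so far:
- compound 1, `COc1cc(N2C(N)=C(C#N)C(c3c(O)ccc4ccccc34)C3=C2CC(C)(C)CC3=O)cc(OC)c1OC`: 143000 nM
- compound 2, `COc1cc(N2C(N)=C(C#N)C(c3ccccc3Cl)C3=C2CC(C)(C)CC3=O)cc(OC)c1OC`: "not active" (no number reported)

In a functional assay on Ehrlich cells (Mus musculus) for cytotoxicity (on this read-out higher numbers stand for weaker inhibition and lower numbers for stronger inhibition), compound 1 gives 143000 nM, a weak effect on this read-out. For compound 2 this assay reports only "not active" (no number reported), so no number stands for it; all that is known is that compound 2 did not reach a measurable effect, and no figure for the gap between compound 1 and compound 2 can be given. The two compounds also differ in more than one place, so nothing about a single change can be read from them.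

Compound 3, `COc1cc(N2C(N)=C(C#N)C(c3ccccc3)C3=C2CC(C)(C)CC3=O)cc(OC)c1OC`, has not yet been measured. It differs from compound 2 only in one spot: hydrogen in place of chloro on an aromatic carbon. Among the compounds with values here, no step between two measured compounds shows what such a change does here, so the size of the step from compound 2 to compound 3 in this assay is unknown; the expectation is a step of no more than the usual scatter, in either direction, starting from a compound that showed no measurable effect.

Compound 3 is therefore expected to give about 250000 nM in this assay, with a range from 60000 nM to 1000000 nM, and a good chance that again only a limit is reported.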

Compound 3, half-maximal inhibitory concentration: "not active" (no number reported)
Compound 3: no number reported; the estimate stays without a comparison.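

Compound 2 and compound 3 both come without a number in this assay, so no step can be read for the change from 2-chlorophenyl to phenyl. No supporting evidence bears on this result. The compounds shown leave open whether chloro or hydrogen at this place changes the effect on these cells at all.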